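Adding a Second Chloro to a Chloromethylbenzyl Purine

The source may report more compounds than this note shows. Statements on the series, on what has been measured and on what is new or still open speak of the compounds shown alone.

Of the compounds shown here, three sharing a fused two-ring core have been tested in a functional assay on M14 cells (Homo sapiens) for cytotoxicity, read by sulforhodamine B assay, with a stated time of 48 h; on this read-out lower numbers stand for higher toxicity in this test and higher numbers for lower toxicity in this test. Compound 1 `ClCc1ccc(Cn2cnc3c(Cl)ncnc32)cc1` gives 9120 nM. Compound 2 `ClCc1ccccc1Cn1cnc2c(Cl)ncnc21` gives 7240 nM, and compound 3 `ClCc1cccc(Cn2cnc3c(Cl)nc(Cl)nc32)c1` gives 6450 nM; both of these numbers lie within the usual scatter of the number for compound 1, so the three cannot be told apart on this read-out.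

Compound 4 `ClCc1ccc(Cn2cnc3c(Cl)nc(Cl)nc32)cc1` has not yet been measured. It differs from compound 1 in a single place: chloro in place of hydrogen on an aromatic carbon. Compound 3 already carries two chloro groups on its core, yet its number sits within the scatter of compound 1, which carries one. Among the measured compounds shown here, there is no measured pair that isolates this exact change, so its effect is open. The expectation is a step no larger than the scatter, in either direction, so the step from compound 1 to compound 4 is estimated at a 1.2-fold lower number from compound 1 to compound 4 (0.08 log units; within the scatter). Compound 4 is therefore expected to give about 7500 nM in this assay, most likely between 3000 nM and 19000 nM.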

Compound 4, concentration lethal to 50% of the cells: 53700 nM
For compound 4 the middle estimate is 7.2-fold (0.85 log units) below the measured one, and the stated range ends below it.
By their numbers in this assay, from the lowest: compounds 3, 2 and 1 (each within the scatter of the next); then compound 4.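

In this assay, a chloro on the aromatic carbon between two ring nitrogen atoms gives a 5.9-fold higher number from compound 1 to compound 4 (0.77 log units; beyond the scatter), the first difference in this set that goes beyond the scatter, so this position does matter on this read-out, and the change moves toward lower toxicity in this test. The chloro alone does not settle the number: compound 3 carries it too and gives 6450 nM, while compound 4 gives 53700 nM, and these two differ only in where the chloromethyl group sits. Nothing shown here explains the size of this step.

The effect of this chloro on compound 2 and on a partner of compound 3 without it cannot be read from these compounds. As far as these compounds go, whether an amine or a methoxy group at the same position would shift the number as far also remains open.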